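A few compounds are considered here, and "the series" means these few. Any claim that something is new, unique, unknown or untested is made for them only; others in the source may bear on it.

Of the compounds shown here, three have been measured in an ADME assay on HepG2 cells (Homo sapiens) for cytotoxicity, read by MTT assay, with a stated time of 48 h; on this read-out lower numbers stand for higher toxicity in this test and higher numbers for lower toxicity in this test. Compound 1 `C#CCN(c1nc(-c2cccc([N+](=O)[O-])c2)no1)C1CCCCC1` gives 45.5 ug/mL, compound 2 `CC(=O)OC[C@H]1O[C@H](OC[C@@H](Cn2cc(CN(c3nc(-c4ccc(F)cc4)no3)C3CCCCC3)nn2)OC(C)=O)C=C[C@@H]1OC(C)=O` gives 28.8 ug/mL, and compound 3 `CC(=O)OC[C@H]1O[C@H](OC[C@@H](Cn2cc(CN(c3nc(-c4ccc(C)cc4)no3)C3CCCCC3)nn2)OC(C)=O)C=C[C@@H]1OC(C)=O` gives 36.8 ug/mL. These values lie within the usual scatter of one another, so compound 1 cannot be separated from either of the other two on these numbers.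

The next compound, compound 4 `C#CCN(c1nc(-c2cccc(C)c2)no1)C1CCCCC1`, differs from compound 1 by one change, methyl in place of nitro on an aromatic carbon, meta to a large group: methyl in place of nitro on an aromatic carbon.

Going by the values given here, only one measured step bears on this change, and only in part. In a 1.3-fold higher number from compound 2 to compound 3 (0.11 log units; within the scatter), methyl also enters on an aromatic carbon, but it replaces fluoro, and the step was measured on much larger molecules. Among the compounds with values here, no measured step shows nitro leaving. Within the data shown here, the evidence is therefore thin, but the one comparable step stays within the scatter, and no step beyond the scatter is expected in this assay, in either direction.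

The estimated 1.1-fold lower number from compound 1 to compound 4 (0.03 log units; within the scatter) is accordingly small. For compound 4 the expected value is 42 ug/mL, with an estimated range from 20 ug/mL to 88 ug/mL.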

Compound 4, half-maximal cytotoxic concentration: 44.4 ug/mL
Beside the measured number, compound 4's estimate is 1.1-fold (0.02 log units) below it, within the range that was stated.
By their numbers in this assay, from the lowest: compounds 2, 3, 4 and 1 (each within the scatter of the next).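

The step of a 1.0-fold lower number from compound 1 to compound 4 (0.01 log units; within the scatter) in this assay is the first shown in which nitro leaves, and it stays within the scatter at this position, on an aromatic carbon meta to a large group. The exchange is not a small one in what is counted: nitro brings three heavy atoms and two hydrogen-bond acceptors, while methyl brings one heavy atom and no acceptors, yet compound 1 and compound 4 cannot be told apart in this read-out. Together with a 1.3-fold higher number from compound 2 to compound 3 (0.11 log units; within the scatter), where methyl replaces fluoro on much larger molecules, this gives two steps that bring in methyl on an aromatic carbon, both within the scatter, and nothing available accounts for why the numbers behave this way.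

The compounds shown leave open whether an amine or a carboxylic acid on this same aromatic carbon, or a longer chain in place of methyl, would give a step beyond the scatter. They also leave open whether methyl in place of nitro would stay within the scatter on another carbon of this ring or on the larger molecules of compound 2 and compound 3.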